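The source may hold more compounds than are shown below. What is called first, only, known or untested is meant among the compounds shown, and "the series" means these compounds.

Compound 3 `COc1ccc(/C=N/N(C)C(=O)c2ccc(OC)c(OC)c2)cc1OC` stands highest of the three compounds measured in a functional assay on the whole organism (strain A/J) for inhibition, with Mus musculus as the target, with stated times of 1 h and 18 h, at a dose of 100 umol/kg by the oral route (a lower number here means less inhibition, a higher number more inhibition at the dose given (going by the name of the read-out)), with compound 3 giving 92%. Compound 2 `COc1cccc(C(=O)N(C)/N=C/c2ccc(OC)c(OC)c2)c1` gives 70%, and compound 1 `COc1ccc(/C=N/N(C)C(=O)c2ccccc2OC)cc1OC` gives 61%. Compound 4 `COc1ccc(C(=O)N(C)/N=C/c2ccc(OC)c(OC)c2)cc1` differs from compound 3 by hydrogen in place of methoxy on an aromatic carbon. Among the measured compounds shown here, the one measured step of the same kind, a number 22 percentage points higher from compound 2 to compound 3 (beyond the scatter), runs in the opposite direction, while a number 9 percentage points higher from compound 1 to compound 2 (within the scatter) shows how little shifting a single methoxy group on that ring can matter. Taking the methoxy group away from compound 3 is therefore expected to cost a modest amount, a number 19 percentage points lower from compound 3 to compound 4 (beyond the scatter). Compound 4 is thus estimated at 73%, with a range from 58% to 88%.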

Compound 4, a percentage reported as inhibition, in the whole organism at one dose (the size of the read-out at that dose, not a potency): 61%
For compound 4 the middle estimate is 12 percentage points above the measured one, within the range that was stated.
By their numbers in this assay, from the lowest: compounds 1, 4 and 2 (each within the scatter of the next); then compound 3.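

Hydrogen in place of methoxy on this aromatic carbon gives a number 31 percentage points lower from compound 3 to compound 4 (beyond the scatter) and so takes away more than the earlier step of the same kind had added. Compound 4 thus shows that either methoxy group of the pair can be lost only at a cost beyond the scatter. With one methoxy group left on that ring, its place makes no readable difference, as a number 9 percentage points lower from compound 2 to compound 4 (within the scatter) and no change at the digits printed from compound 1 to compound 4 (within the scatter) show.

Nothing at hand explains why the pair counts for more than a single methoxy group. As far as these compounds go, how an ethoxy group, a chlorine atom or an amine would fare at this place remains open.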